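This account rests on a few compounds, and the source may have more. Where it says the series, first, only, none or still open, it means among the compounds named here.

Among the compounds with values here, compound 1 `CN(CC(=O)N1CCN(c2ccccc2)CC1)C(=O)c1ccc(S(C)(=O)=O)c([N+](=O)[O-])c1` is one of only two compounds that have been measured in an assay on isolated protein for inhibition of thyroid hormone receptor alpha (Homo sapiens), read by fluorescence polarization; a lower number here means a stronger inhibitor, a higher number a weaker inhibitor. In this assay compound 1 gives no number, only a limit, > 60000 nM. Compound 2 `CS(=O)(=O)c1ccc(C(=O)NCCCC(=O)N2CCC(c3ccccc3)CC2)cc1[N+](=O)[O-]` likewise gives only a limit in this assay, > 60000 nM. Both results sit at the limit of > 60000 nM in this assay, at which 2 of the 2 values shown sit, so neither compound can be placed above or below the other, and compound 1 stands exactly where compound 2 stands. Compound 3 `CN(CC(=O)N1CCN(c2ccc(F)cc2)CC1)C(=O)c1ccc(S(C)(=O)=O)c([N+](=O)[O-])c1` differs from compound 1 in a single place: fluoro in place of hydrogen on an aromatic carbon. Within the data shown here, no step between two measured compounds is available, so this change has no measured counterpart here. A change this small is expected to move the result little, if at all, beyond the usual scatter. Compound 3 is therefore expected to give 100000 nM, between 40000 nM and 300000 nM, most probably again only as a limit. The expected step that the limit leaves unreadable from compound 1 to compound 3 is essentially none.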

Compound 3, half-maximal inhibitory concentration: > 60000 nM
Compound 3 was reported as a limit (the forecaster's own chance of this, stated with the estimate: 85%); the middle value lies beyond the limit too.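

Compound 1 and compound 3 each give only a limit in this assay, so the size of the step between them cannot be read. The compounds shown leave open whether any change to the core of compound 1 would yield a measurable number in this assay.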